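A few compounds are considered here, and "the series" means these few. Any claim that something is new, unique, unknown or untested is made for them only; others in the source may bear on it.

Measured compounds and their values in a functional assay on HT-29 cells (Homo sapiens) for cytotoxicity, read by MTT assay, with a stated time of 72 h; a lower number here means a stronger inhibitor, a higher number a weaker inhibitor:

Compound 1, `Cc1ccc(NC(=O)Nc2ccc(-c3nc(NCCCN(C)C)c4sc(Cl)c(Cl)c4n3)cc2)cc1`: 1320 nM
Compound 2, `CCN(CC)CCNc1nc(-c2ccc(NC(=O)Nc3ccc(F)cc3)cc2)nc2c(Cl)c(Cl)sc12`: 650 nM
Compound 3, `CCN(CC)CCNc1nc(-c2ccc(NC(=O)Nc3ccccc3Cl)cc2)nc2c(Cl)c(Cl)sc12`: 550 nM

Among these three, compound 3 gives the lowest number in this assay. Compound 2 sits within the scatter of it, so the two cannot be told apart, while compound 1 lies beyond the scatter with a higher number.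

Compound 4, `CCN(CC)CCNc1nc(-c2ccc(NC(=O)Nc3ccc(C)cc3)cc2)nc2c(Cl)c(Cl)sc12`, has not yet been measured. It differs from compound 3 in one place: 4-methylphenyl in place of 2-chlorophenyl on an amide-type nitrogen.

Going by the values given here, one measured step bears on this kind of change, an exchange of the aromatic group on the amide-type nitrogen: a 1.2-fold lower number from compound 2 to compound 3 (0.07 log units; within the scatter). That exchange moved the number hardly at all. Among the compounds with values here, compound 1 also carries 4-methylphenyl, but with a different amine chain, so its value shows only that this group can sit in a compound with a higher number; no single step connects it to compound 3 or compound 4.

On this basis the expected step in this assay is small, and compound 4 is estimated at 800 nM, within 350 nM to 1800 nM. This estimate corresponds to the expected step of a 1.5-fold higher number from compound 3 to compound 4 (0.16 log units; within the scatter).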

Compound 4, half-maximal inhibitory concentration: 950 nM
Beside the measured number, compound 4's estimate is 1.2-fold (0.07 log units) below it; measured number inside the range.
By their numbers in this assay, from the lowest: compounds 3, 2, 4 and 1 (each within the scatter of the next, the first and the last beyond it).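

In this assay, 4-methylphenyl in place of 2-chlorophenyl on the amide-type nitrogen gives a 1.7-fold higher number from compound 3 to compound 4 (0.24 log units; within the scatter) and methyl in place of fluoro on the aromatic carbon gives a 1.5-fold higher number from compound 2 to compound 4 (0.16 log units; within the scatter) so the three aromatic groups tried at this position, all with the diethylamino chain, cannot be told apart. The amine chain can now be compared with 4-methylphenyl held fixed, and diethylamino in place of (dimethylamino)methyl gives a 1.4-fold lower number from compound 1 to compound 4 (0.14 log units; within the scatter) which also stays within the scatter. Nothing measured here gives a reason for these small steps.

Still open, on these data alone, is whether an aromatic group carrying an amine or a carboxylic acid, or cyclohexyl in place of the aromatic group, would move the number beyond the scatter. A longer chain on the amine side also remains an open question.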